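The source may report more compounds than this note shows. Statements on the series, on what has been measured and on what is new or still open speak of the compounds shown alone.

Measured so far in an assay on CHO cells for displacement of a labelled ligand from adenosine receptor A3 (Homo sapiens), read by scintillation counting, with a stated time of 120 min, tested at 1 uM; a lower number here means less inhibition, a higher number more inhibition at the concentration tested (going by the name of the read-out):

compound 1, `Cc1nc2sc(-c3cccc(C(F)(F)F)c3)nc2c(=O)[nH]1`, 15%
compound 2, `Cc1nc2sc(-c3cccnc3)nc2c(=O)[nH]1`, 33%
compound 3, `Cc1nc2sc(-c3ccco3)nc2c(=O)[nH]1`, 20%

Among these three numbers compound 3 holds the second highest. Its nearest neighbour is compound 1, whose value lies within the usual scatter of the read-out, so the two cannot be told apart on this evidence. The furthest is compound 2, which sits higher by a margin beyond the scatter.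

Compound 4, `Cc1nc2sc(-n3ccnc3)nc2c(=O)[nH]1`, has not yet been measured. It differs from compound 3 in one place: 1H-imidazol-1-yl in place of furan-2-yl on an aromatic carbon.

Among the compounds with values here, no pair of measured compounds differs in one place, so there is no measured step to lean on. Within the data shown here, the only hint is that compound 2, giving 33%, carries a ring with nitrogen in the same position, while the furan-2-yl of compound 3 and the trifluoromethyl-bearing ring of compound 1 sit lower. On that basis a change of a number 5 percentage points higher from compound 3 to compound 4 (within the scatter) is expected, an upward drift that stays within the scatter rather than a clear step. Compound 4 is therefore expected to give about 25%, with a range from 8% to 45%.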

Compound 4, a percentage reported as inhibition, at one concentration (the size of the read-out at that concentration, not a potency): 8%
Estimate against measurement, compound 4: 17 percentage points above; low and high end bracket the measured number.
By their numbers in this assay, from the lowest: compounds 4, 1 and 3 (each within the scatter of the next, the first and the last beyond it); then compound 2.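

In this assay, within the data shown here, exchanging furan-2-yl for 1H-imidazol-1-yl on the aromatic carbon next to the ring nitrogen and next to the ring sulfur gives a number 12 percentage points lower from compound 3 to compound 4 (beyond the scatter), the first single change at this position that can be read. The number here thus shifts with the identity of the five-membered aromatic ring, even though both groups have 5 heavy atoms. Nitrogen in the attached ring does not go with a higher number on its own: compound 2 gives 33% while compound 4 gives 8%. Nothing available explains this step.

The compounds shown leave open how an amine or a plain phenyl ring would read at this position. Going by these compounds, all four carry the same methyl group on the core, so the effect of a longer chain there also remains open.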